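The source may hold more compounds than are shown below. What is called first, only, known or untested is meant among the compounds shown, and "the series" means these compounds.

Of the compounds shown here, three built on a shared core have been tested in a functional assay on SK-OV-3 cells (Homo sapiens) for cytotoxicity, read by MTT assay, with a stated time of 48 h; on this read-out higher numbers stand for weaker inhibition and lower numbers for stronger inhibition. Compound 1, `O=C(/C=C/c1ccc2c(c1)B(O)OC2)c1ccc(-c2ccccc2)cc1`, gives 4900 nM in this assay. Compound 2, `O=C(/C=C/c1ccc2c(c1)B(O)OC2)c1cccnc1`, gives 18500 nM in this assay, which is the highest of the three numbers, so it is the weakest inhibitor shown here. Compound 3, `Cc1ccc(C(=O)/C=C/c2ccc3c(c2)B(O)OC3)cc1C`, gives 1900 nM in this assay, the lowest of the three. The two nearest neighbours of compound 2 on this scale are compound 1 and then compound 3, both clearly stronger than compound 2 by gaps beyond the scatter.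

The next compound to be examined is compound 4, `O=C(/C=C/c1ccc2c(c1)B(O)OC2)c1cccc(O)c1`. Its structure differs from compound 2 in one place: 3-hydroxyphenyl in place of pyridin-3-yl on a carbonyl carbon. The other two carbon-only aromatic rings on this carbonyl carbon, in compound 1 and compound 3, sit well below compound 2, which is the only ground for an expectation here. The step of a 3.1-fold lower number from compound 2 to compound 4 (0.49 log units; beyond the scatter) is expected to bring compound 4 down toward those neighbours, in the direction of stronger inhibition. Compound 4 is therefore estimated to give about 6000 nM in this assay, within a range from 2000 nM to 18000 nM.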

Compound 4, half-maximal inhibitory concentration: 3800 nM
For compound 4 the middle estimate is 1.6-fold (0.20 log units) above the measured one, and the stated range covers the measured number.
By their numbers in this assay, from the lowest: compounds 3, 4 and 1 (each within the scatter of the next, the first and the last beyond it); then compound 2.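

Among these compounds, on the carbonyl carbon, 3-hydroxyphenyl in place of pyridin-3-yl gives a 4.9-fold lower number from compound 2 to compound 4 (0.69 log units; beyond the scatter) in this assay, which is the first step here that can be read across a change in one place. The swap does two things at once: the ring loses its nitrogen and becomes carbon only, and a hydroxyl group arrives, taking the hydrogen-bond donors from 0 to 1, so this single step cannot say which part carries the difference. No measurement shown here gives a reason for the step.

Going by these compounds, an unsubstituted phenyl ring on this carbonyl carbon would separate the loss of the ring nitrogen from the gain of the hydroxyl, and that comparison remains open. On these data alone, whether an amine or a carboxylic acid in place of the hydroxyl would give a similar number also remains open.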